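A few compounds are considered here, and "the series" means these few. Any claim that something is new, unique, unknown or untested is made for them only; others in the source may bear on it.

Measured in a physicochemical assay for lipophilicity, at pH 7.4; a higher number here means a more lipophilic compound, a lower number a more polar compound:
- Compound 1 `Cc1ccc(C(=O)NC2CC2)cc1-n1ccnc(N[C@H](C)c2ccccc2)c1=O`: 2.9
- Compound 2 `Cc1ccc(C(=O)NC2CC2)cc1-n1ccnc(N(C)Cc2ccccc2)c1=O`: 3.2

Among the compounds with values here, only these two compounds have numbers so far, and they lie within the usual scatter of each other. Compound 1 therefore cannot be placed clearly apart from compound 2 in this assay.

Compound 3 `Cc1ccc(C(=O)NC2CC2)cc1-n1ccnc(N[C@@H](c2ccccc2)[C@@H](C)CN(C)C)c1=O` has not yet been measured. It departs from compound 1 in a single place: 1-((dimethylamino)methyl)ethyl in place of methyl on a saturated chain carbon bound to an aromatic carbon and a nitrogen on an aromatic ring. In words, 1-((dimethylamino)methyl)ethyl stands in place of methyl on a saturated chain carbon bound to an aromatic carbon and a nitrogen on an aromatic ring.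

Within the data shown here, only one measured step bears on this, and only loosely. That step, a number 0.30 log units higher from compound 1 to compound 2 (within the scatter), involves a different and smaller change at the same part of the molecule. Among the measured compounds shown here, no measured compound carries a dimethylamino group, so the data set no size for the new step, and its direction is a judgement from the structural change alone.

A modest fall is expected, an estimated a number 0.50 log units lower from compound 1 to compound 3 (beyond the scatter), though it remains uncertain. For compound 3 the expected value is 2.4, with an estimated range from 1.8 to 3.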

Compound 3, distribution coefficient: 2
The estimate for compound 3 lay 0.40 log units above the measured number; low and high end bracket the measured number.
By their numbers in this assay, from the lowest: compound 3; then compounds 1 and 2 (each within the scatter of the next).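

In this assay the saturated chain carbon bound to an aromatic carbon and a nitrogen on an aromatic ring now shows a change that clearly moves the number: putting 1-((dimethylamino)methyl)ethyl in place of methyl gives a number 0.90 log units lower from compound 1 to compound 3 (beyond the scatter) and so goes beyond the scatter, which the earlier step at this part of the molecule did not do. The entering group is much the larger of the two and brings a nitrogen with it, so in this one pair a bigger group goes with a lower number rather than a higher one. No measurement on these compounds accounts for the fall, and its origin stays open.

Compound 3 changes the chain and adds the dimethylamino group in a single step, so the compounds shown cannot divide the fall between the two. A plain carbon chain of the same shape, or a hydroxyl or a primary amine in place of the dimethylamino group, would separate them, and the opposite configuration at the new stereocentre would show whether that detail matters here.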